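A few compounds are considered here, and "the series" means these few. Any claim that something is new, unique, unknown or untested is made for them only; others in the source may bear on it.

Compound 1 `CCN(CC)C(=O)COc1ccc2cc(C(O)(C(F)(F)F)C(F)(F)F)c(O)cc2c1` and compound 2 `O=C(COc1ccc2cc(C(O)(C(F)(F)F)C(F)(F)F)c(O)cc2c1)NCc1ccccc1` share one core and differ only in the amide. In an assay on isolated protein for inhibition of receptor-type tyrosine-protein phosphatase C (Homo sapiens), read by spectrophotometry (a higher number here means a weaker inhibitor, a lower number a stronger inhibitor), compound 1 gives > 20000 nM, which is a limit of the assay rather than a number. In this assay compound 2 likewise gives > 20000 nM, again a limit. So the step that the two limits leave unreadable from compound 1 to compound 2 cannot be read, and compound 2 stands only at the limit of > 20000 nM in this assay, at which 2 of the 2 values shown sit. Compound 3 `O=C(COc1ccc2cc(C(O)(C(F)(F)F)C(F)(F)F)c(O)cc2c1)NCc1ccc(F)cc1` carries the change (fluoro in place of hydrogen on an aromatic carbon). Among the measured compounds shown here, no measured step speaks to this change, and the step that the limit leaves unreadable from compound 2 to compound 3 is therefore only an expectation of no readable shift. Compound 3 is expected at 30000 nM, within 8000 nM to 100000 nM.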

Compound 3, half-maximal inhibitory concentration: > 20000 nM
Compound 3 gave a limit, no number; the forecaster's own chance of this, stated with the estimate: 85%; the middle value is on the limit's open side.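

Among the compounds shown here, compound 3 also sits at a limit of the assay rather than a number, so no step from compound 1 or compound 2 to compound 3 can be read: the limit of > 20000 nM in this assay, at which 3 of the 3 values shown sit. From the compounds shown here alone, whether the fluoro group or either amide changes inhibition at all in this assay stays open.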